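The source may hold more compounds than are shown below. What is called first, only, known or untested is meant among the compounds shown, and "the series" means these compounds.

The measured compounds in a functional assay on HepG2 cells (Homo sapiens) for antiproliferative activity, read by MTT assay, with a stated time of 48 h; a higher number here means a weaker inhibitor, a lower number a stronger inhibitor:
compound 1, `N#CC1=C(N)Oc2c(c3nc4ccccc4nc3c3ccccc23)C12C(=O)N(Cc1cnnn1-c1ccc(Br)cc1)c1ccccc12`: > 50000 nM
compound 2, `N#CC1=C(N)Oc2c(c3nc4ccccc4nc3c3ccccc23)C12C(=O)N(Cc1cnnn1-c1ccccc1Br)c1ccccc12`: > 50000 nM
compound 3, `Cc1cccc(-n2nncc2CN2C(=O)C3(C(C#N)=C(N)Oc4c(N)cc5nc6ccccc6nc5c43)c3ccccc32)c1`: > 50000 nM

Each of these three values is a limit of this assay and not a number. Compound 1 reaches only the limit of > 50000 nM. Compound 2 likewise gives only a limit, > 50000 nM. Compound 3 also stands at a limit, > 50000 nM; the two further values shown are limits as well, so compound 3 cannot be ordered against them in this assay. Among the measured compounds shown here, the single step between measured compounds that differ in one place, a step that the two limits leave unreadable from compound 1 to compound 2, is unreadable, because both of its ends sit at the limit of > 50000 nM in this assay, at which 3 of the 3 values shown sit.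

Compound 4, `CCc1cccc(CC)c1-n1nncc1CN1C(=O)C2(C(C#N)=C(N)Oc3c(N)cc4nc5ccccc5nc4c32)c2ccccc21`, is the compound yet to be measured in this assay. It differs from compound 3 in one place: 2,6-diethylphenyl in place of 3-methylphenyl on an aromatic nitrogen. For the measured compounds named here, no measured step gives a readable size for a change on this aromatic nitrogen, so there is nothing to suggest a move away from the limit. Compound 4 is therefore expected to remain at the limit of this assay, with an estimated value of 60000 nM, in a range of 20000 nM to 200000 nM. The expected step, a step that the limit leaves unreadable from compound 3 to compound 4, is thus estimated as none beyond the scatter.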

Compound 4, half-maximal inhibitory concentration: 16500 nM
Beside the measured number, compound 4's estimate is 3.6-fold (0.56 log units) above it, outside the stated range (below it).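

In this assay, this aromatic nitrogen turns out to be a position where a change can move the result: 2,6-diethylphenyl in place of 3-methylphenyl gives an at least 3.0-fold lower number from compound 3 to compound 4 (0.48 log units; beyond the scatter). Compound 4, at 16500 nM, is the only compound shown with a number and not a limit, and the earlier step between compound 1 and compound 2 cannot be read. The size of the new step is only a minimum, because its starting end is a limit of the assay: the limit of > 50000 nM in this assay, at which 3 of the 4 values shown sit.

From the compounds shown here alone, it stays open which part of the change matters, the two ethyl groups together or the place they occupy on the phenyl ring, and whether a 2,6-dimethylphenyl, a 2-ethylphenyl or a 2,6-diisopropylphenyl on this nitrogen would also come away from the limit. Also open, going by these compounds, is whether the same 2,6-diethylphenyl would give a readable number on the core of compound 1, and whether an amine or a carboxylic acid on the phenyl ring would do the same.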